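The source may hold more compounds than are shown below. What is called first, only, known or untested is meant among the compounds shown, and "the series" means these compounds.

Compound 1, `Cc1c(Br)cc2nc3n(c2c1Br)[C@H]1OC[C@@H](OS(C)(=O)=O)[C@H]1OC3`, gives 23700 nM in an ADME assay on HEp-2 cells (Homo sapiens) for cytotoxicity, read by MTT assay, with a stated time of 60 h; on this read-out lower numbers stand for higher toxicity in this test and higher numbers for lower toxicity in this test.
Compound 2, `O[C@@H]1CO[C@H]2[C@@H]1OCc1nc3cc(Br)c(Br)cc3n12`, gives 181000 nM in this assay.
Compound 3, `Cc1c(Br)cc2nc3n(c2c1Br)[C@H]1OC[C@@H](O)[C@H]1OC3`, gives 250000 nM in this assay.

The study turns on a single change made twice. Compound 3 and compound 1 differ by methylsulfonyl in place of hydrogen on an oxygen on a saturated carbon, and in this assay that change produced an 11-fold lower number from compound 3 to compound 1 (1.02 log units; beyond the scatter). Compound 2 and compound 4, `CS(=O)(=O)O[C@@H]1CO[C@H]2[C@@H]1OCc1nc3cc(Br)c(Br)cc3n12`, differ by methylsulfonyl in place of hydrogen on an oxygen on a saturated carbon, the same change at the same kind of place; the places are described in the same words. How the core of compound 2 differs from the core of compound 3 is not broken down here. In this assay compound 2 gives a number close to that of compound 3, within the scatter of the method, so the two cores start from about the same level before the change is applied. Compound 4 has not yet been measured in this assay.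

Because the earlier change gave an 11-fold lower number from compound 3 to compound 1 (1.02 log units; beyond the scatter), and because compound 2 starts at 181000 nM, a step of similar size is expected from compound 2 to compound 4, namely a 10-fold lower number from compound 2 to compound 4 (1.00 log units; beyond the scatter). That rests on one pair only, so the range is kept wide. Compound 4 is therefore expected to give about 18000 nM in this assay, most likely between 6000 nM and 60000 nM.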

Compound 4, half-maximal cytotoxic concentration: 99500 nM
The estimate for compound 4 lay 5.5-fold (0.74 log units) below the measured number; measured number above the stated range.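

On the core of compound 2, the methylsulfonyl group in place of hydrogen on an oxygen on a saturated carbon gave a 1.8-fold lower number from compound 2 to compound 4 (0.26 log units; within the scatter) in this assay, so the change left no clear mark on this core. Set beside the earlier step, this shows that the size of the change did not carry over from one core to the other, and that a step read on one core could not be taken as it stood to the other: the same change on two cores in this assay, an 11-fold lower number (1.02 log units; beyond the scatter) from compound 3 to compound 1 and a 1.8-fold lower number (0.26 log units; within the scatter) from compound 2 to compound 4, 5.8-fold (0.76 log units) apart, beyond the scatter of two such steps. For the compounds shown here, it does not show which difference between the cores goes with the gap, nor how the change would behave on any further core, since each core supplies only a single pair and the numbers describe cytotoxicity in this one test alone.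

The compounds shown leave open whether the gap belongs to methylsulfonyl in particular or would also appear with another group on the same oxygen, such as an acetyl group or the longer ethylsulfonyl. They also leave open whether an amine in place of the hydroxy group would give similar or different steps on the two cores.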